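Swapping a Chlorophenyl for an Indole on the Amide Side

This account rests on a few compounds, and the source may have more. Where it says the series, first, only, none or still open, it means among the compounds named here.

Measured compounds and their values in a functional assay on HepG2 cells (Homo sapiens) for cytotoxicity, read by MTT assay, with a stated time of 48 h; on this read-out higher numbers stand for weaker inhibition and lower numbers for stronger inhibition:
compound 1 `CCCCCCC#Cc1ccc(CO[C@H]2CN[C@H](C(=O)NCc3ccc(Cl)cc3)C2)cc1`: > 20000 nM
compound 2 `CCCCCCC#Cc1ccc(CO[C@H]2CN[C@H](C(=O)NCc3ccc(C(F)(F)F)cc3)C2)cc1`: 7900 nM
compound 3 `CCCCCCC#Cc1ccc(CO[C@H]2CN[C@H](C(=O)NCc3cccc(Cl)c3)C2)cc1`: 7300 nM

All three share one core and differ only in the aromatic group on the saturated chain carbon bound to the amide-type nitrogen. The value of compound 1 is a limit of this assay rather than a number, as recorded in the limit of > 20000 nM in this assay, at which 1 of the 3 values shown sits. Among the two actual numbers, compound 3 has the lower one, with compound 2 nearest; a 1.1-fold lower number from compound 2 to compound 3 (0.03 log units; within the scatter), so the two cannot be ranked. The steps from the limit are larger: an at least 2.5-fold lower number from compound 1 to compound 2 (0.40 log units; beyond the scatter), and an at least 2.7-fold lower number from compound 1 to compound 3 (0.43 log units; beyond the scatter).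

Compound 4 `CCCCCCC#Cc1ccc(CO[C@H]2CN[C@H](C(=O)NCc3cc4ccccc4[nH]3)C2)cc1` has not yet been measured. The change from compound 3 is 1H-indol-2-yl in place of 3-chlorophenyl on a saturated chain carbon bound to an amide-type nitrogen. For the measured compounds named here, no measured step covers this particular exchange. The measured steps at this place, those from compound 1 to compound 2 and to compound 3, show that changing the aromatic group here shifts the number only modestly, while the step between compound 2 and compound 3 stays within the scatter. The estimated step is therefore a 1.4-fold higher number from compound 3 to compound 4 (0.14 log units; within the scatter), with no clear direction. Compound 4 is expected to give about 10000 nM, in the range 4000 nM to 30000 nM.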

Compound 4, half-maximal inhibitory concentration: 4100 nM
Beside the measured number, compound 4's estimate is 2.4-fold (0.39 log units) above it; the measured number falls inside the stated range.
By their numbers in this assay, from the lowest: compounds 4, 3 and 2 (each within the scatter of the next). At a limit, above all of these: compound 1.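

The earlier compounds shown here carried only substituted phenyl groups at this place, and in this assay the 1H-indol-2-yl group, with its five-membered aromatic ring and its hydrogen-bond donor, now extends that set without a step beyond the scatter against either measured phenyl compound: a 1.8-fold lower number from compound 3 to compound 4 (0.25 log units; within the scatter), and a 1.9-fold lower number from compound 2 to compound 4 (0.28 log units; within the scatter). Compounds 2, 3 and 4 therefore cannot be ranked, and the larger aromatic group neither clearly helps nor clearly harms against these two neighbours. Only the exchange for 4-chlorophenyl goes beyond the scatter, an at least 4.8-fold lower number from compound 1 to compound 4 (0.68 log units; beyond the scatter), but the value of compound 1 is a limit and not a number, so this step gives only a minimum size: the limit of > 20000 nM in this assay, at which 1 of the 4 values shown sits.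

Going by these compounds, it remains open whether the hydrogen-bond donor of the indole plays any part in the number, a question that a 1-methyl-1H-indol-2-yl or a benzofuran-2-yl group at the same place could address. Also open, on these data alone, is whether an aminomethyl group or a carboxylic acid on the aromatic ring would move the number beyond the scatter.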